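The source may report more compounds than this note shows. Statements on the series, on what has been measured and on what is new or still open speak of the compounds shown alone.

The series shares one core and is followed here in a physicochemical assay for lipophilicity; a higher number here means a more lipophilic compound, a lower number a more polar compound. Compound 1 `CN(C)CCCn1cc[n+](C)c1/C=N/O` reaches only the limit of this assay, < -3, and this is the limit of < -3 in this assay, at which 1 of the 3 values shown sits. Compound 2 `CCN(CC)CCCn1cc[n+](C)c1/C=N/O` gives -2.78 in this assay. Compound 3 `CN(CCCn1cc[n+](C)c1/C=N/O)S(C)(=O)=O` gives -2.63 in this assay, which is the highest of the two numbers, with compound 2 as its nearest neighbour; the step of a number 0.15 log units higher from compound 2 to compound 3 (within the scatter) lies within the scatter. The remaining steps are a number at least 0.22 log units higher from compound 1 to compound 2 (that floor lies within the scatter) and a number at least 0.37 log units higher from compound 1 to compound 3 (beyond the scatter).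

Compound 4 `C[n+]1ccn(CCCC(C)(C)[N+](=O)[O-])c1/C=N/O` has not yet been measured. It differs from compound 3 in one place: 1-methyl-1-nitroethyl in place of methyl(methylsulfonyl)amino on a saturated chain carbon, three bonds along the chain from an aromatic nitrogen. Within the data shown here, no measured step exchanges exactly these two groups. The two steps at the same chain position, a number at least 0.22 log units higher from compound 1 to compound 2 (that floor lies within the scatter) and a number 0.15 log units higher from compound 2 to compound 3 (within the scatter), were small, and only a number at least 0.37 log units higher from compound 1 to compound 3 (beyond the scatter) went clearly beyond the scatter. A step of no more than modest size, in either direction and possibly within the scatter, is therefore expected here. The step of a number 0.13 log units higher from compound 3 to compound 4 (within the scatter) is the expected change. Compound 4 is expected to give -2.5 in this assay, with a likely range from -3 to -2.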

Compound 4, distribution coefficient: -2.18
For compound 4 the middle estimate is 0.32 log units below the measured one, and the stated range covers the measured number.
By their numbers in this assay, from the lowest: compounds 2 and 3 (each within the scatter of the next); then compound 4. At a limit, below all of these: compound 1.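

Among these compounds, at this position, on a saturated chain carbon, three bonds along the chain from an aromatic nitrogen, 1-methyl-1-nitroethyl is the first group to stand clearly apart from both other groups that carry a number in this assay: the exchange gives a number 0.45 log units higher from compound 3 to compound 4 (beyond the scatter), and likewise a number 0.60 log units higher from compound 2 to compound 4 (beyond the scatter), whereas compound 2 and compound 3 lie within the scatter of each other. The group that leaves and the group that enters match in heavy atoms, hydrogen-bond donors, hydrogen-bond acceptors and net charge, and differ in the sulfur, one carbon and one double bond, so these matching counts alone do not fix the value here. Compound 1 stands at a limit and not at a number, so the remaining exchange gives only a floor, a number at least 0.82 log units higher from compound 1 to compound 4 (beyond the scatter): the limit of < -3 in this assay, at which 1 of the 4 values shown sits.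

The compounds shown do not tell whether the difference follows the nitro group or the two methyl groups of 1-methyl-1-nitroethyl, which a tert-butyl group or an unbranched nitroalkyl chain at the same place could separate. They also leave open whether the same group would give a similar step on a longer chain.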